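Notes on pyrrolidine amide and sulfonamide variations

This account rests on a few compounds, and the source may have more. Where it says the series, first, only, none or still open, it means among the compounds named here.

Measured compounds:
compound 1 `CN1CCN(c2ccc(Nc3ncc4nc(Nc5ccc(F)cc5)n([C@@H]5CCN(C(=O)CO)C5)c4n3)cc2)CC1` 350 nM
compound 2 `CN1CCN(c2ccc(Nc3ncc4nc(Nc5ccc(F)cc5)n([C@H]5CCCN(S(=O)(=O)C6CC6)C5)c4n3)cc2)CC1` 8.6 nM
compound 3 `CN1CCN(c2ccc(Nc3ncc4nc(Nc5ccccc5)n([C@H]5CCN(S(C)(=O)=O)C5)c4n3)cc2)CC1` 17 nM

Compound 3 sits second highest of the three numbers in a functional assay on HCC827 cells (Homo sapiens) for antiproliferative activity, read by MTT assay, with a stated time of 72 h; on this read-out higher numbers stand for weaker inhibition and lower numbers for stronger inhibition. Its nearest neighbour is compound 2, whose number is lower by a gap that stays within the scatter; compound 1 is furthest, with a number higher than that of compound 3 well beyond the scatter.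

Compound 4 `CN1CCN(c2ccc(Nc3ncc4nc(Nc5ccccc5)n([C@@H]5CCN(C(=O)OC(C)(C)C)C5)c4n3)cc2)CC1` is not yet measured. It differs from compound 3 by 1-(tert-butoxycarbonyl)pyrrolidin-3-yl in place of 1-(methylsulfonyl)pyrrolidin-3-yl on an aromatic nitrogen. Within the data shown here, the one measured step that bears on this is a 41-fold lower number from compound 1 to compound 2 (1.61 log units; beyond the scatter), where a carbonyl-linked group on the saturated ring was exchanged for a sulfonyl-linked one; that step is large, though the two structures also differ elsewhere, so the comparison is not clean. Going from compound 3 to compound 4 reverses the direction of that exchange, sulfonyl out and carbonyl in, so some loss is expected, tempered by the uncertainty of the single comparison: the estimated step is a 3.5-fold higher number from compound 3 to compound 4 (0.55 log units; beyond the scatter). For compound 4 the expected value in this assay is 60 nM, with a range from 15 nM to 250 nM.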

Compound 4, half-maximal inhibitory concentration: 12 nM
The estimate for compound 4 lay 5.0-fold (0.70 log units) above the measured number; the whole stated range lies above it.
By their numbers in this assay, from the lowest: compounds 2, 4 and 3 (each within the scatter of the next); then compound 1.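

In this assay, the exchange of 1-(methylsulfonyl)pyrrolidin-3-yl for 1-(tert-butoxycarbonyl)pyrrolidin-3-yl on the aromatic nitrogen gives a 1.4-fold lower number from compound 3 to compound 4 (0.15 log units; within the scatter) with the anilino group unchanged, so a sulfonyl link is not required at this position for a low number. The position also accepts the entering group of 12 heavy atoms in place of the leaving group of 9 without a change beyond the scatter. The large step of a 41-fold lower number from compound 1 to compound 2 (1.61 log units; beyond the scatter) therefore cannot be assigned to the carbonyl or sulfonyl link alone, and the hydroxymethyl group of compound 1 and the ring size remain unseparated from it.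

The compounds shown leave open what a free secondary amine on the pyrrolidine would give. They also leave open whether a longer chain on the sulfonyl group would keep the number low. No further data bear on this result.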